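The source may hold more compounds than are shown below. What is called first, only, known or untested is meant among the compounds shown, and "the series" means these compounds.

Working notes on the series. Compound 1 `Cc1ccc2c(=O)[nH]c(-c3ccccc3N(C)C)nc2c1` and compound 2 `Cc1ccc2nc(-c3cccc(OC(F)(F)F)c3)[nH]c(=O)c2c1` share one core and differ in the group carried on the pendant aromatic ring. In an assay on isolated protein for inhibition of DNA topoisomerase 1 (Homo sapiens), with a stated time of 30 min, tested at 20 uM (a lower number here means a weaker effect, a higher number a stronger effect of the compound at the concentration tested), compound 1 gives 5.3%, and compound 2 gives 0%; the two numbers lie within the scatter of each other, so neither is set apart from the other, and both show essentially no inhibition. Compound 3 `COc1cccc(-c2nc3ccc(C)cc3c(=O)[nH]2)c1` has not yet been measured in this assay. Its difference from compound 2 is methyl in place of trifluoromethyl on an oxygen on an aromatic ring. Among the measured compounds shown here, with both measured neighbours showing essentially no inhibition and no step between measured compounds available, no guidance exists for this change; the expected step of a number 3 percentage points higher from compound 2 to compound 3 (within the scatter) is none beyond the scatter. In this assay compound 3 is therefore estimated at 3%, in the range 0% to 15%.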

Compound 3, a percentage reported as inhibition, at one concentration (the size of the read-out at that concentration, not a potency): 0%
Estimate against measurement, compound 3: 3 percentage points above; the measured number falls inside the stated range.
By their numbers in this assay, from the lowest: compounds 2, 3 and 1 (each within the scatter of the next).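

In this assay the exchange of trifluoromethoxy for methoxy gives no change at the digits printed from compound 2 to compound 3 (within the scatter), the first step read at a single place in the series. With methyl in place of trifluoromethyl on this oxygen, the read-out stays at essentially no inhibition at the concentration tested, so this change alone does not lift either compound clear of the scatter. No available measurement accounts for this outcome.

The step starts and ends at essentially no inhibition, so it leaves open whether this position can influence the read-out in a compound with clear inhibition. Also open, going by these compounds, is whether a longer chain on the oxygen, or an amine or a carboxylic acid in place of the ether group, would give a number beyond the scatter.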